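The compounds below may be only part of what the source reports. "The series", "measured", "known", "first", "only" and "open" are said of these compounds alone.

Measured compounds:
- compound 1 `CN(C)C(=O)c1cc2cnc(Nc3ccc(NC(=O)C4(C(=O)Nc5cccc(O)c5)CC4)cc3)nc2n1C1CCCC1`, in a functional assay on NCI-H460 cells (Homo sapiens) for inhibition, read by CCK-8 assay, with a stated time of 72 h, tested at 1 uM (on this read-out lower numbers stand for less inhibition of growth and higher numbers for more inhibition of growth at the one concentration tested), compound 1 gives 75.5%
- compound 2 `CN(C)C(=O)c1cc2cnc(Nc3ccc(NC(=O)C4(C(=O)Nc5ccc(F)cc5)CC4)cc3F)nc2n1C1CCCC1`, in this assay compound 2 gives 11.9%

Compound 1 stands highest of the two numbers; its nearest neighbour, compound 2, lies far lower, by a margin well beyond the scatter. Within the data shown here, compound 2 differs from compound 1 in more than one place, so its value gives no single-change step and only marks how wide the range within this shared core can be.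

The next compound to be measured is compound 3 `CN(C)C(=O)c1cc2cnc(Nc3ccc(NC(=O)C4(C(=O)Nc5ccc(Cl)cc5)CC4)cc3)nc2n1C1CCCC1`. It departs from compound 1 at a single place: 4-chlorophenyl in place of 3-hydroxyphenyl on an amide-type nitrogen. The group that leaves brings 1 hydrogen-bond donor and 1 hydrogen-bond acceptor; the one that enters brings none of either. Among the measured compounds shown here, no measured pair in this set isolates a change of this kind, so the size of the step in this assay is open; some loss relative to compound 1 seems the more likely direction, with no firm ground to call it large or small.

For compound 3 the expected value in this assay is 42%, within a range of 12% to 72%, which is an estimated step of a number 33.5 percentage points lower from compound 1 to compound 3 (beyond the scatter).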

Compound 3, percent growth inhibition at one concentration: 21.3%
Beside the measured number, compound 3's estimate is 20.7 percentage points above it; measured number inside the range.
By their numbers in this assay, from the lowest: compounds 2 and 3 (each within the scatter of the next); then compound 1.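

In this assay, among these compounds, the aryl group on the amide-type nitrogen gives the first single-change reading: 4-chlorophenyl in place of 3-hydroxyphenyl gives a number 54.2 percentage points lower from compound 1 to compound 3 (beyond the scatter) at this position. The two groups have the same heavy-atom count and the same six-membered aromatic carbon ring, and differ in the substituent and its place on that ring, so the position responds strongly to a change that leaves the ring itself untouched. The 3-hydroxyphenyl group brings a hydrogen-bond donor and acceptor and the 4-chlorophenyl group brings neither, but nothing at hand ties the step to the loss of the hydroxyl, to the arrival of the chlorine, or to the different placement of the substituent.

This single pair cannot separate those three readings, nor say whether the hydroxyl raises the number or the chlorine lowers it. Unsubstituted phenyl, 4-hydroxyphenyl and 3-chlorophenyl on the same nitrogen would pull them apart, and 3-aminophenyl or 3-methoxyphenyl would test whether anything other than the hydroxyl can stand in that place.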